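Swapping bromophenyl for phenylethenyl in a bovine kidney cytotoxicity assay

The source may report more compounds than this note shows. Statements on the series, on what has been measured and on what is new or still open speak of the compounds shown alone.

Two close analogues have been measured in an ADME assay on MDBK cells (Bos taurus) for cytotoxicity; a lower number here means that less compound is tolerated, a higher number that more compound is tolerated. Compound 1 `Brc1cccc(Cn2ccc3nc(-c4ccccc4)nc-3c2)c1` gives 85000 nM in this assay, and compound 2 `Brc1ccc(Cn2ccc3nc(-c4ccccc4)nc-3c2)cc1` gives 83000 nM. For the measured compounds named here, the only step between them is a 1.0-fold lower number from compound 1 to compound 2 (0.01 log units; within the scatter), so compound 2 sits alongside compound 1 with no separation that the assay can resolve.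

Compound 3 `C(=C/c1ccccc1)\Cn1ccc2nc(-c3ccccc3)nc-2c1` is not yet measured. It differs from compound 2 as follows: 2-phenylethenyl in place of 4-bromophenyl on a saturated chain carbon bound to an aromatic nitrogen. Going by the values given here, the only measured step bears on the same attachment point, the saturated chain carbon bound to an aromatic nitrogen, but it concerns only the position of the bromine on the ring, whereas here the whole 4-bromophenyl group is replaced by 2-phenylethenyl. That step, a 1.0-fold lower number from compound 1 to compound 2 (0.01 log units; within the scatter), stayed within the scatter, which suggests the assay is not sensitive to small changes at this position, but it gives no direct guide to the present change. With nothing in the data pointing in either direction, the expected step of a 1.0-fold lower number from compound 2 to compound 3 (0.02 log units; within the scatter) is one of no change beyond the scatter. Compound 3 is therefore estimated at 80000 nM, with a range from 35000 nM to 190000 nM.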

Compound 3, half-maximal cytotoxic concentration: 78000 nM
The estimate for compound 3 lay 1.0-fold (0.01 log units) above the measured number; the measured number falls inside the stated range.
By their numbers in this assay, from the lowest: compounds 3, 2 and 1 (each within the scatter of the next).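

Where the earlier pair only moved the bromine around the ring, compound 3 replaces the whole group at this place, and in this assay the outcome is still small: the readings are a 1.1-fold lower number from compound 2 to compound 3 (0.03 log units; within the scatter) and a 1.1-fold lower number from compound 1 to compound 3 (0.04 log units; within the scatter). Losing the bromine and bringing in 2-phenylethenyl, with its double bond outside aromatic rings, therefore leaves no separation the assay can resolve, so on the saturated chain carbon bound to an aromatic nitrogen these three compounds show that a change of the whole group, and not only a shift of the bromine, can pass without a visible difference. The data at hand offer no measurement that would explain this result.

On these data alone, all three groups at this place carry a six-membered aromatic ring of carbon only, with no net charge and no hydrogen-bond donors or acceptors, so it remains open whether the same picture would hold for an amine or a carboxylic acid on this carbon. The phenyl on the shared core is identical in all three compounds, so they say nothing about a change there.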